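A few compounds are considered here, and "the series" means these few. Any claim that something is new, unique, unknown or untested is made for them only; others in the source may bear on it.

Series notes. Compound 1 `NCCCOc1ccc(CNc2ccc(Oc3ccccc3)cc2)cc1` is measured in an assay on isolated protein for inhibition of Voltage-dependent N-type calcium channel subunit alpha-1B (Rattus norvegicus) (a lower number here means that less compound is needed, a higher number that more compound is needed for the effect), and compound 1 gives 34000 nM. Compound 2 `NC(N)=NCCCOc1ccc(CNc2ccc(Oc3ccccc3)cc2)cc1` carries a group of 4 heavy atoms (1 carbon, 3 nitrogen; no ring) in place of one nitrogen atom, on a saturated chain carbon, three bonds along the chain from an oxygen on an aromatic ring; in this assay compound 2 gives 21000 nM, and the step is a 1.6-fold lower number from compound 1 to compound 2 (0.21 log units; within the scatter). Compound 3 `NCCCOc1ccc(CNC(c2ccccc2)c2ccccc2)cc1` has a different core; the difference between the two cores is not broken down here. In this assay compound 3 yields only a limit, > 100000 nM, which is the limit of > 100000 nM in this assay, at which 1 of the 3 values shown sits. Compound 4 `NC(N)=NCCCOc1ccc(CNC(c2ccccc2)c2ccccc2)cc1` stands to compound 3 as compound 2 stands to compound 1, with the same change, (a group of 4 heavy atoms (1 carbon, 3 nitrogen; no ring) in place of one nitrogen atom, on a saturated chain carbon, three bonds along the chain from an oxygen on an aromatic ring), at the same place. Because a 1.6-fold lower number from compound 1 to compound 2 (0.21 log units; within the scatter) lies within the scatter, a step of the same size is expected here, a number no higher from compound 3 to compound 4 (the limit leaves the size open). Compound 4 is accordingly estimated at 100000 nM, with a range from 40000 nM to 300000 nM, and a limit rather than a number is the likelier report.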

Compound 4, half-maximal effective concentration: 23000 nM
Compound 4: middle estimate off by 4.3-fold (0.64 log units), on the high side; measured number outside the range, below it.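

On the core of compound 3, the group of 4 heavy atoms (1 carbon, 3 nitrogen) in place of the amino group gives, in this assay, an at least 4.3-fold lower number from compound 3 to compound 4 (0.63 log units; beyond the scatter). Going by these compounds, this does not show that the change carries over with a larger effect on this core than on the core of compound 1: the same change on two cores in this assay, a 1.6-fold lower number (0.21 log units; within the scatter) from compound 1 to compound 2 and an at least 4.3-fold lower number (0.63 log units; beyond the scatter) from compound 3 to compound 4; the limit leaves it open whether they differ Compound 3 gives only a limit, > 100000 nM, and not a number, so the size of this step remains unknown.

Still open, on these data alone, is how a longer chain carrying the same group would read in this assay. The same holds for a carboxylic acid in place of that group on either core.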